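A few compounds are considered here, and "the series" means these few. Any claim that something is new, unique, unknown or untested is made for them only; others in the source may bear on it.

Compound 3, `CC1CC/C(=N\Nc2cccc(Br)c2)c2ncc(C(=O)O)c(=O)n21`, was tested in a functional assay on the whole organism for inhibition, with Rattus norvegicus as the target; a lower number here means that less compound is needed, a higher number that more compound is needed for the effect. Compound 3 gives only a limit there, > 320 umol/kg. Compound 1, `CC1CC/C(=N\Nc2ccccc2F)c2ncc(C(=O)O)c(=O)n21`, also gives a limit in this assay, > 1000 umol/kg. Compound 2, `CC1CC/C(=N\Nc2ccccc2Cl)c2ncc(C(=O)O)c(=O)n21`, likewise gives a limit, > 1000 umol/kg. The steps a step that the two limits leave unreadable from compound 1 to compound 2, a step that the two limits leave unreadable from compound 1 to compound 3 and a step that the two limits leave unreadable from compound 2 to compound 3 therefore carry no readable size. Compound 4, `CC1CC/C(=N\Nc2ccc(Br)cc2)c2ncc(C(=O)O)c(=O)n21`, differs from compound 3 as follows: 4-bromophenyl in place of 3-bromophenyl on an amine nitrogen. Among the compounds with values here, no measured step resembles this change, and the two limits, the limit of > 1000 umol/kg in this assay, at which 2 of the 3 values shown sit, and (the limit of > 320 umol/kg in this assay, at which 1 of the 3 values shown sits), give no direction. Compound 4 is expected to give a limit as well, with an estimated value of 1000 umol/kg between 300 umol/kg and 3000 umol/kg. The expected step that the limit leaves unreadable from compound 3 to compound 4 is judged as none beyond the scatter.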

Compound 4, dose for 50% inhibition: > 1000 umol/kg
Compound 4 gave a limit, no number; the forecaster's own chance of this, stated with the estimate: 85%; the middle value sits exactly at the limit.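

In this assay compound 4 gives only a limit, > 1000 umol/kg, so its steps from compound 1, compound 2 and compound 3 cannot be read. The compounds shown leave open whether changing the aromatic group on the amine nitrogen alters the dose needed at all.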